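A few compounds are considered here, and "the series" means these few. Any claim that something is new, unique, unknown or untested is made for them only; others in the source may bear on it.

Compound 1 `COc1cc(-c2cc(C(=O)O)c3ccccc3n2)ccc1OCC(=O)Nc1ccccc1` was examined in an ADME assay on HaCaT cells (Homo sapiens) for inhibition; a lower number here means a stronger inhibitor, a higher number a weaker inhibitor. In this assay compound 1 gives only a limit of the assay, > 300000 nM, and not a number. Two further compounds share its core and differ from it in one place. Compound 2 `COc1cc(-c2cc(C(=O)O)c3ccccc3n2)ccc1OCC(=O)Nc1ccccc1C` gives 230000 nM in this assay, and compound 3 `COc1cc(-c2cc(C(=O)O)c3ccccc3n2)ccc1OCC(=O)Nc1ccccc1C(F)(F)F` gives 102000 nM. The measured steps read an at least 1.3-fold lower number from compound 1 to compound 2 (0.11 log units; that floor lies within the scatter), an at least 2.9-fold lower number from compound 1 to compound 3 (0.46 log units; beyond the scatter) and a 2.3-fold lower number from compound 2 to compound 3 (0.35 log units; beyond the scatter). Compound 4 `COc1cc(-c2cc(C(=O)O)c3ccccc3n2)ccc1OCC(=O)NCc1cccnc1` has not yet been measured in this assay. It differs from compound 1 by (pyridin-3-yl)methyl in place of phenyl on an amide-type nitrogen. Among the compounds with values here, none of the measured steps touches the amide-type nitrogen; each of them exchanges a hydrogen on the phenyl ring that now leaves, so they carry little over to this exchange of the whole group. Because compound 1 sits at the limit of > 300000 nM in this assay, at which 1 of the 3 values shown sits, the step for compound 4 is expected to be a number no higher from compound 1 to compound 4 (the limit leaves the size open), with a fair chance that only a limit is reported again. Compound 4 is therefore estimated at 300000 nM, between 100000 nM and 1000000 nM.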

Compound 4, half-maximal inhibitory concentration: > 300000 nM
Compound 4: no number, only a limit (the forecaster's own chance of this, stated with the estimate: 65%); the middle value lies on the limit itself.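

In this assay compound 4 gives only a limit of the assay, > 300000 nM, and not a number. This first change at the amide-type nitrogen gives an at least 2.9-fold higher number from compound 3 to compound 4 (0.46 log units; beyond the scatter) and an at least 1.3-fold higher number from compound 2 to compound 4 (0.11 log units; that floor lies within the scatter), so of the two substituted phenyl groups only the 2-(trifluoromethyl)phenyl group of compound 3 is clearly set apart from (pyridin-3-yl)methyl. The step from compound 1 cannot be read, because compound 1 and compound 4 both sit at the limit: the limit of > 300000 nM in this assay, at which 2 of the 4 values shown sit.

The compounds shown leave open what a benzyl group on the amide-type nitrogen would give, and so whether the ring nitrogen or the longer link of (pyridin-3-yl)methyl matters. Also open, on these data alone, is whether a trifluoromethyl group on the (pyridin-3-yl)methyl ring would bring a readable number.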